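Moving the Chlorine Around the Chlorophenyl Ring

A few compounds are considered here, and "the series" means these few. Any claim that something is new, unique, unknown or untested is made for them only; others in the source may bear on it.

Compound 3 `O=S(=O)(c1cc(Cl)cc(Cl)c1)c1cnc2c(F)cccc2c1-c1cccc(Cl)c1` is one of three compounds tested in an ADME assay on microsomes from liver (Homo sapiens) for metabolic stability, tested at 2.5 uM (on this read-out lower numbers stand for slow clearance and higher numbers for fast clearance), where compound 3 gives 1.2 mL/min. That is the largest of the three numbers recorded: compound 1 `O=S(=O)(c1cccc(F)c1)c1cnc2c(F)cccc2c1-c1ccc(Cl)cc1` gives 0.62 mL/min, which lies within the scatter of compound 3, while compound 2 `N#Cc1cccc(S(=O)(=O)c2cnc3c(F)cccc3c2-c2ccc(Cl)cc2)c1` gives 0.08 mL/min, well beyond it. Going by the values given here, the only single-point step recorded, a 7.8-fold lower number from compound 1 to compound 2 (0.89 log units; beyond the scatter), concerns a different part of the molecule. Compound 4 `O=S(=O)(c1cc(Cl)cc(Cl)c1)c1cnc2c(F)cccc2c1-c1ccc(Cl)cc1` differs from compound 3 in one place: 4-chlorophenyl in place of 3-chlorophenyl on an aromatic carbon. Among the compounds with values here, no measured step bears on this change, so no shift beyond the scatter is expected, and the estimated step is a 1.2-fold lower number from compound 3 to compound 4 (0.08 log units; within the scatter). Compound 4 is therefore expected to give 1 mL/min, with a range from 0.5 mL/min to 2 mL/min.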

Compound 4, intrinsic clearance in a liver preparation (reported as CLH), per the amount of preparation that the assay uses: 0.78 mL/min
Compound 4: the middle estimate sits 1.3-fold (0.11 log units) above what was measured, within the range that was stated.
By their numbers in this assay, from the lowest: compound 2; then compounds 1, 4 and 3 (each within the scatter of the next).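

In this assay, moving the chlorine gives a 1.5-fold lower number from compound 3 to compound 4 (0.19 log units; within the scatter), so swapping 3-chlorophenyl for 4-chlorophenyl at this position does not separate the two compounds beyond the scatter. On the sulfonyl sulfur, 3,5-dichlorophenyl in place of 3-fluorophenyl gives a 1.3-fold higher number from compound 1 to compound 4 (0.10 log units; within the scatter), while in place of 3-cyanophenyl it gives a 9.8-fold higher number from compound 2 to compound 4 (0.99 log units; beyond the scatter), a step beyond the scatter. Nothing available explains these numbers. As far as these compounds go, whether an amine or a methoxy group in place of the chlorine on this ring would move the number remains open. So does whether 3-cyanophenyl on the sulfonyl sulfur would give a similar step alongside 3-chlorophenyl.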